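A Methoxy-for-Chloro Swap on an Inactive Chalcone Imidazolone

The source may hold more compounds than are shown below. What is called first, only, known or untested is meant among the compounds shown, and "the series" means these compounds.

Compound 1 `COc1cc(/C=C/C(=O)c2cccc(-n3cc(-c4ccc(Cl)cc4)[nH]c3=O)c2)cc(OC)c1OC` was tested in a functional assay on HOP-62 cells (Homo sapiens) for inhibition (a higher number here means a weaker inhibitor of growth, a lower number a stronger inhibitor of growth), and came out as "not active" (no number reported) there, so no single number can be set against it. Among the measured compounds shown here, a related compound 2 `O=C(/C=C/c1cccc(O)c1)c1cccc(-n2cc(-c3ccc(Cl)cc3)[nH]c2=O)c1`, which shares the core but carries a different aryl group on the enone, gives 2360 nM in this assay, and that is the only number available. Compound 3 `COc1ccc(-c2cn(-c3cccc(C(=O)/C=C/c4cc(OC)c(OC)c(OC)c4)c3)c(=O)[nH]2)cc1` is formed from compound 1 by the change (methoxy in place of chloro on an aromatic carbon), a small replacement on an aromatic carbon of a six-membered aromatic ring of carbon only, para to a large group. For the measured compounds named here, with no measured step to lean on, no shift beyond the scatter is anticipated from this exchange, and compound 3 is expected to remain a weak inhibitor of growth. Compound 3 is therefore estimated at 20000 nM, within a range from 5000 nM to 80000 nM, with a real chance that only a limit is reported.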

Compound 3, concentration for 50% growth inhibition: 5910 nM
For compound 3 the middle estimate is 3.4-fold (0.53 log units) above the measured one, and the stated range covers the measured number.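

Among the compounds shown here, with compound 1 at "not active" (no number reported) and compound 3 at 5910 nM no step between compound 1 and compound 3 can be read. On these data alone, how far 4-chlorophenyl to 4-methoxyphenyl moves growth inhibition stays open. No evidence at hand bears on this result.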